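Thiophene in place of acetoxyphenyl on a sulfonyl enone

The source may hold more compounds than are shown below. What is called first, only, known or untested is meant among the compounds shown, and "the series" means these compounds.

Among the measured compounds shown here, compound 2 `CC(=O)Oc1ccc(/C=C(\C(=O)c2ccc(Cl)cc2)S(=O)(=O)c2ccc(C)cc2)cc1` stands at the weak end of the three compounds measured so far. In a functional assay on DU-145 cells (Homo sapiens) for inhibition, read by trypan blue exclusion, with a stated time of 96 h (a lower number here means a stronger inhibitor of growth, a higher number a weaker inhibitor of growth), compound 2 gives 25000 nM, which at the digits shown is level with compound 3 `Cc1ccc(S/C(=C/c2c(F)c(F)c(F)c(F)c2F)C(=O)c2ccc(Cl)cc2)cc1` at 25000 nM; these two values lie within the scatter of each other, so no order between them can be drawn. For the measured compounds named here, the only compound clearly apart is compound 1 `Cc1ccc(S(=O)(=O)/C(=C/c2ccccc2F)C(=O)c2ccc(Cl)cc2)cc1`, which gives 2500 nM. Going by the values given here, one measured step bears directly on the new compound: a 10-fold higher number from compound 1 to compound 2 (1.00 log units; beyond the scatter), where 4-acetoxyphenyl in place of 2-fluorophenyl made the growth inhibitor weaker.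

Compound 4 `Cc1ccc(S(=O)(=O)/C(=C/c2cccs2)C(=O)c2ccc(Cl)cc2)cc1` arises from compound 2 by the change (thiophen-2-yl in place of 4-acetoxyphenyl on a double-bonded chain carbon bound to a double-bonded chain carbon). This takes away the 4-acetoxyphenyl whose arrival in compound 2 raised the number, and puts another aromatic ring in its place. Among the compounds with values here, because a 10-fold higher number from compound 1 to compound 2 (1.00 log units; beyond the scatter) was a clear loss, undoing it is expected to bring the number back down, though compound 1 and compound 4 have no measured pair between them, so how far the recovery goes is uncertain. Compound 4 is therefore expected to show a 5.0-fold lower number from compound 2 to compound 4 (0.70 log units; beyond the scatter) in this assay. The estimate for compound 4 is 5000 nM, with a range from 1500 nM to 20000 nM.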

Compound 4, concentration for 50% growth inhibition: 25000 nM
For compound 4 the middle estimate is 5.0-fold (0.70 log units) below the measured one; the measured number lies above the stated range.
By their numbers in this assay, from the lowest: compound 1; then compounds 2, 3 and 4 (each within the scatter of the next).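

In this assay the change to thiophen-2-yl gives no change at the digits printed from compound 2 to compound 4 (within the scatter) so, at this position on a double-bonded chain carbon bound to a double-bonded chain carbon, this assay does not separate the two groups, although thiophen-2-yl has fewer heavy atoms than 4-acetoxyphenyl. The result also shows that the loss is not confined to 4-acetoxyphenyl: replacing 2-fluorophenyl with thiophen-2-yl gives a 10-fold higher number from compound 1 to compound 4 (1.00 log units; beyond the scatter) and the earlier replacement with 4-acetoxyphenyl gives a 10-fold higher number from compound 1 to compound 2 (1.00 log units; beyond the scatter) so two quite different aromatic rings end up in the same place, with compound 1 alone set apart among these three close relatives. No experimental evidence is available here to explain this pattern.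

The compounds shown leave open whether the lower number of compound 1 belongs to the fluorine itself or to the six-membered ring that carries it, a question that plain phenyl at this position would address. They also leave open how a phenyl ring bearing an amine or a carboxylic acid would behave at the same place.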